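Swapping the aryl group on the acrylamide arm

This account rests on a few compounds, and the source may have more. Where it says the series, first, only, none or still open, it means among the compounds named here.

Compound 3 `O=C(/C=C/c1ccc(F)cc1Cl)Nc1cc2c(Nc3ccc(F)c(Cl)c3)ncnc2cc1O[C@H]1CCOC1` is the stronger of the two compounds with a reported number in a functional assay on PC-3 cells (Homo sapiens) for cytotoxicity, read by MTT assay, with a stated time of 72 h; a higher number here means a weaker inhibitor, a lower number a stronger inhibitor. Compound 2 `O=C(/C=C/c1cc(Br)c(O)c(Br)c1)Nc1cc2c(Nc3ccc(F)c(Cl)c3)ncnc2cc1O[C@H]1CCOC1` differs from it only in the aryl group on the acrylamide arm, and in this assay compound 2 gives 25500 nM, while compound 3 gives 7150 nM. For the measured compounds named here, the only measured step is a 3.6-fold lower number from compound 2 to compound 3 (0.55 log units; beyond the scatter). A third compound, compound 1 `COc1cc2ncnc(Nc3ccc(F)c(Cl)c3)c2cc1NC(=O)/C=C/c1ccc(C#N)cc1`, carries a methoxy group on the shared core in place of the tetrahydrofuranyloxy group and the same 4-cyanophenyl arm that compound 4 will carry; in this assay compound 1 gives "not active" (no number reported), so no number is known for it.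

Compound 4 `N#Cc1ccc(/C=C/C(=O)Nc2cc3c(Nc4ccc(F)c(Cl)c4)ncnc3cc2O[C@H]2CCOC2)cc1` is compound 3 with one change: 4-cyanophenyl in place of 2-chloro-4-fluorophenyl on a double-bonded chain carbon bound to a double-bonded chain carbon. Going by the values given here, no measured step covers this exact exchange, so the estimate rests on the only aryl-swap step seen, from compound 2 to compound 3, and on the missing activity of compound 1, which shares the 4-cyanophenyl arm. Compound 4 is therefore expected to be weaker than compound 3, with an estimated step of a 2.8-fold higher number from compound 3 to compound 4 (0.45 log units; beyond the scatter). The estimated value for compound 4 in this assay is 20000 nM, within a range from 7000 nM to 60000 nM.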

Compound 4, half-maximal inhibitory concentration: 36600 nM
Compound 4: middle estimate off by 1.8-fold (0.26 log units), on the low side; the measured number falls inside the stated range.
By their numbers in this assay, from the lowest: compound 3; then compounds 2 and 4 (each within the scatter of the next).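

At this position, on a double-bonded chain carbon bound to a double-bonded chain carbon, a second aryl exchange away from 2-chloro-4-fluorophenyl also raises the number in this assay (a 5.1-fold higher number from compound 3 to compound 4 (0.71 log units; beyond the scatter)), so compound 3 now stands as the most potent of the three compounds with numbers. The two arms that replace it cannot be told apart here, even though 4-cyanophenyl and 3,5-dibromo-4-hydroxyphenyl share little beyond the aromatic ring (a 1.4-fold higher number from compound 2 to compound 4 (0.16 log units; within the scatter)). Nothing measured here accounts for the advantage of the 2-chloro-4-fluorophenyl arm.

Compound 1 has the same 4-cyanophenyl arm as compound 4 on a methoxy-bearing core. Here compound 1 gives "not active" (no number reported), so the step between the two cannot be read and the effect of the tetrahydrofuranyloxy group remains unknown. The compounds shown also leave open whether both halogens of the favoured arm are needed, and how an unsubstituted phenyl, a 4-fluorophenyl, a 2-chlorophenyl or an arm ending in an amine or a carboxylic acid would compare with compound 3.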